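Opening the Amide: Methylamino in Place of Morpholin-4-yl

A few compounds are considered here, and "the series" means these few. Any claim that something is new, unique, unknown or untested is made for them only; others in the source may bear on it.

Of the compounds shown here, three sharing one core have been measured in an assay on a protein complex for inhibition of CDK8/Cyclin C (Homo sapiens), with a stated time of 1 h, tested at 10 uM; on this read-out higher numbers stand for more inhibition at the one concentration tested (going by the name of the read-out) and lower numbers for less inhibition. Compound 1 `O=C(O)COc1ccncc1-c1ccc2ccccc2c1` gives 16%, compound 2 `CCOC(=O)/C=C/c1ccncc1-c1ccc2ccccc2c1` gives 102%, and compound 3 `O=C(CCc1ccncc1-c1ccc2ccccc2c1)N1CCOCC1` gives 100%. Among the compounds with values here, the only single-point step among them, a number 86 percentage points higher from compound 1 to compound 2 (beyond the scatter), concerns the group on the aromatic carbon. On these numbers compound 3 stands within the scatter of compound 2 and far above compound 1.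

Compound 4 `CNC(=O)CCc1ccncc1-c1ccc2ccccc2c1` differs from compound 3 at the amide end: methylamino in place of morpholin-4-yl on a carbonyl carbon. Within the data shown here, no measured step bears on this kind of change; the step from compound 1 to compound 2 alters a different part of the molecule and so gives no guide to the size or direction of the step here. Because compound 3 already gives 100%, little room remains upward, and the change is small, so a step of about a number 5 percentage points lower from compound 3 to compound 4 (within the scatter) is expected, none beyond the scatter. Compound 4 is therefore estimated at 95%, with a range from 75% to 105%.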

Compound 4, a percentage reported as inhibition, at one concentration (the size of the read-out at that concentration, not a potency): 100%
Compound 4: middle estimate off by 5 percentage points, on the low side; the measured number falls inside the stated range.
By their numbers in this assay, from the lowest: compound 1; then compounds 3, 4 and 2 (each within the scatter of the next).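

In this assay the number stays level across a large change in size at the amide end: swapping morpholin-4-yl, with its ring and six heavy atoms, for methylamino, with two heavy atoms and no ring, gives (no change at the digits printed from compound 3 to compound 4 (within the scatter)). The new compound also sits close to the unsaturated ester (a number 2 percentage points lower from compound 2 to compound 4 (within the scatter)) and remains far from the carboxymethoxy compound (a number 84 percentage points higher from compound 1 to compound 4 (beyond the scatter)), so among these four compounds only compound 1 stands apart.

On these data alone, with compounds 2, 3 and 4 so close together at a single concentration, any differences in potency among them stay hidden, and it remains open whether a carboxylic acid at the end of the saturated chain of compound 4, or a bare primary amide there, would hold the read-out. No measurement available explains why the number stays level across this change at the amide end.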